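Nitro in place of trifluoromethyl on the shared core

The source may report more compounds than this note shows. Statements on the series, on what has been measured and on what is new or still open speak of the compounds shown alone.

In a physicochemical assay for solubility (a higher number here means a more soluble compound, a lower number a less soluble compound), compound 1 `O=C(Nc1ccccc1Cl)c1cc(Cl)ccc1O` gives 5 ug/mL. Compound 2 `O=C(Nc1ccccc1C(F)(F)F)c1cc(Cl)ccc1O` gives > 47 ug/mL, which is a limit of the assay and not a number. Compound 3 `O=C(Nc1ccccc1[N+](=O)[O-])c1cc(Cl)ccc1O` differs from compound 2 as follows: nitro in place of trifluoromethyl on an aromatic carbon. Among the compounds with values here, the only measured step bearing on this change is an at least 9.4-fold higher number from compound 1 to compound 2 (0.97 log units; beyond the scatter), which lies beyond the scatter. That step brings in the trifluoromethyl group that now leaves, but it compares this group with chloro. Within the data shown here, no measured step involves nitro, so the size of the change is poorly fixed. Compound 3 is expected to give back part of the gain seen in an at least 9.4-fold higher number from compound 1 to compound 2 (0.97 log units; beyond the scatter). The estimated step is an at least 3.3-fold lower number from compound 2 to compound 3 (0.52 log units; beyond the scatter), towards a lower number in this assay and beyond the scatter. For compound 3 the estimate is 14 ug/mL, with an expected range of 4 ug/mL to 45 ug/mL.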

Compound 3, solubility: 15.4 ug/mL
Compound 3: middle estimate off by 1.1-fold (0.04 log units), on the low side; the measured number falls inside the stated range.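

On this aromatic carbon, nitro can now be set against both earlier groups in this assay. Nitro in place of trifluoromethyl gives an at least 3.0-fold lower number from compound 2 to compound 3 (0.48 log units; beyond the scatter) and nitro in place of chloro gives a 3.1-fold higher number from compound 1 to compound 3 (0.49 log units; beyond the scatter) so, with both steps beyond the scatter, the three compounds separate, with chloro lowest, trifluoromethyl highest and nitro in the middle. The value of compound 2 is a limit and not a number, so the step to nitro fixes only a bound and not a size: the limit of > 47 ug/mL in this assay, at which 1 of the 3 values shown sits.

As far as these compounds go, how far trifluoromethyl truly stands above nitro remains open. Also open, from the compounds shown here alone, are where an amine or a carboxylic acid on this carbon would fall in this assay and whether the order of the three groups holds on any core other than the shared one.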